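The compounds below may be only part of what the source reports. "The series", "measured", "known", "first", "only" and "open" are said of these compounds alone.

Compound 1 `Cc1ccc(CS/C(=C/c2ccc(O)c(O)c2O)C(=O)c2ccc(Cl)cc2)cc1` gives 50000 nM in a functional assay on DU-145 cells (Homo sapiens) for inhibition, read by trypan blue exclusion, with a stated time of 96 h (a higher number here means a weaker inhibitor of growth, a lower number a stronger inhibitor of growth), and compound 2 `Cc1ccc(CS/C(=C/c2cc([N+](=O)[O-])ccc2F)C(=O)c2ccc(Cl)cc2)cc1` gives 1000 nM there.

Compound 2 at 1000 nM holds the lower of the two numbers. Compound 3 `Cc1ccc(CS/C(=C/c2cccc(Cl)c2Cl)C(=O)c2ccc(Cl)cc2)cc1` has 2,3-dichlorophenyl in place of 2-fluoro-5-nitrophenyl on a double-bonded chain carbon bound to a double-bonded chain carbon in the same core. Going by the values given here, the only measured step at this place is a 50-fold lower number from compound 1 to compound 2 (1.70 log units; beyond the scatter) and it is large, beyond the scatter, but it involves neither the entering group nor a clear direction for it. A moderate rise in this assay is expected, estimated as a 3.0-fold higher number from compound 2 to compound 3 (0.48 log units; beyond the scatter) and no more than that. For compound 3 the estimated value is 3000 nM with an expected range from 600 nM to 15000 nM in this assay.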

Compound 3, concentration for 50% growth inhibition: 25000 nM
Compound 3: the middle estimate sits 8.3-fold (0.92 log units) below what was measured; the measured number lies above the stated range.
By their numbers in this assay, from the lowest: compound 2; then compounds 3 and 1 (each within the scatter of the next).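

In this assay this position proves to depend on more than the absence of hydroxyl groups: 2,3-dichlorophenyl also has no hydrogen-bond donors, yet the change gives a 25-fold higher number from compound 2 to compound 3 (1.40 log units; beyond the scatter) and does not hold the number of compound 2. The other new step is a 2.0-fold lower number from compound 1 to compound 3 (0.30 log units; within the scatter) and places 2,3-dichlorophenyl level with 2,3,4-trihydroxyphenyl, so among these three only 2-fluoro-5-nitrophenyl gives the lower number. Nothing available explains this difference.

Which part of 2-fluoro-5-nitrophenyl carries the lower number stays open. So does how an amine or a carboxylic acid on this ring would read.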